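Cyano in Place of Fluoro: An Expected Step

The source may report more compounds than this note shows. Statements on the series, on what has been measured and on what is new or still open speak of the compounds shown alone.

Of the compounds shown here, three sharing one core have been tested in a functional assay on HCT-15 cells (Homo sapiens) for inhibition, read by sulforhodamine B assay; on this read-out higher numbers stand for weaker inhibition of growth and lower numbers for stronger inhibition of growth. Compound 1 `O=C(CCC1=CCN(Cc2ccc(F)cc2)C1=O)NO` gives 4070 nM. Compound 3 `O=C(CCC1=CCN(Cc2cccc(Cl)c2)C1=O)NO` gives 4720 nM, a number that lies within the usual scatter of the number for compound 1. Compound 2 `Cc1ccc(CCCCN2CC=C(CCC(=O)NO)C2=O)cc1` gives 8540 nM, a higher number that lies beyond that scatter, so compound 1 stands at the low end of the three. The step under consideration leads from compound 1 to compound 4 `N#Cc1ccc(CN2CC=C(CCC(=O)NO)C2=O)cc1`: cyano in place of fluoro on an aromatic carbon. For the measured compounds named here, no measured pair shows this change, so its size is unknown from the data. The step of a 1.2-fold lower number from compound 1 to compound 4 (0.07 log units; within the scatter) is expected to stay within the scatter, leaning slightly toward a lower number. Compound 4 is estimated at 3500 nM, in a range from 1500 nM to 9000 nM.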

Compound 4, concentration for 50% growth inhibition in the HCT-15 assay: > 10000 nM
Compound 4 gave a limit, no number; the forecaster's own chance of this, stated with the estimate: 2%; middle value at least 2.8-fold (0.45 log units) from the limit.
By their numbers in the HCT-15 assay, from the lowest: compounds 1, 3 and 2 (each within the scatter of the next, the first and the last beyond it). At a limit, above all of these: compound 4.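

In the HCT-15 assay, this position on the aromatic carbon, para to a large group, proves sensitive to the change, with cyano in place of fluoro giving an at least 2.4-fold higher number from compound 1 to compound 4 (0.39 log units; beyond the scatter). Compound 4 gives > 10000 nM, which is a limit of the assay and not a number. In a physicochemical assay for lipophilicity (a lower number here means a more polar compound, a higher number a more lipophilic compound), compound 1 gives 0.571 and compound 4 gives 0.197. In the physicochemical assay compound 4 is the more polar of the pair, which may contribute to its weaker inhibition of growth: the measured distribution coefficient of compound 1, 0.571, and of compound 4, 0.197, a number 0.37 log units lower (beyond the scatter)

A single pair cannot separate that polarity from other effects of the cyano group. Going by these compounds, whether a methoxy group or an amine on this carbon would keep the growth inhibition of compound 1 remains open.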